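The source may report more compounds than this note shows. Statements on the series, on what has been measured and on what is new or still open speak of the compounds shown alone.

Compound 1 `COC(=O)[C@@]1(C)CCC=C2[C@@H]1CC[C@@H](C)[C@]2(C)Cc1c[nH]c2ccccc12`: 3600 nM
Compound 2 `COC(=O)[C@@]1(C)CCC=C2[C@@H]1CC[C@@H](C)[C@]2(C)Cc1c[nH]c2ccc(C)cc12`: 14000 nM
Compound 3 `COC(=O)[C@@]1(C)CCC=C2[C@@H]1CC[C@@H](C)[C@]2(C)Cc1c[nH]c2ccc(F)cc12`: 3700 nM

In a functional assay on HeLa cells (Homo sapiens) for inhibition, read by sulforhodamine B assay, with a stated time of 48 h (on this read-out higher numbers stand for weaker inhibition of growth and lower numbers for stronger inhibition of growth), compound 3 gives 3700 nM, the second highest of the three numbers. Its nearest neighbour is compound 1, and the step of a 1.0-fold higher number from compound 1 to compound 3 (0.01 log units; within the scatter) keeps the two within the scatter. The furthest is compound 2, from which the step of a 3.8-fold lower number from compound 2 to compound 3 (0.58 log units; beyond the scatter) is beyond the scatter.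

Compound 4 `COC(=O)[C@@]1(C)CCC=C2[C@@H]1CC[C@@H](C)[C@]2(C)Cc1c[nH]c2ccc(OC)cc12` differs from compound 3 by methoxy in place of fluoro on an aromatic carbon. Among the compounds with values here, two measured steps bear on this substituent position. The step of a 3.9-fold higher number from compound 1 to compound 2 (0.59 log units; beyond the scatter) shows that a methyl there raised the number modestly, whereas the step of a 1.0-fold higher number from compound 1 to compound 3 (0.01 log units; within the scatter) shows that a fluoro there left it unchanged. Within the data shown here, a methoxy at this position has no direct precedent among the three, so the expectation rests on the methyl step. On that basis compound 4 is expected to show a modest rise in this assay, that is a 1.9-fold higher number from compound 3 to compound 4 (0.28 log units; within the scatter). Compound 4 is therefore estimated at 7000 nM, with a range from 2500 nM to 20000 nM.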

Compound 4, concentration for 50% growth inhibition: 1200 nM
Beside the measured number, compound 4's estimate is 5.8-fold (0.77 log units) above it; measured number outside the range, below it.
By their numbers in this assay, from the lowest: compound 4; then compounds 1 and 3 (each within the scatter of the next); then compound 2.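

In this assay, within the data shown here, methoxy is the first group at this aromatic carbon to lower the number relative to the unsubstituted compound, with a 3.0-fold lower number from compound 1 to compound 4 (0.48 log units; beyond the scatter), so this position is not limited to leaving growth inhibition unchanged or weakening it. The comparison with the other substituents points the same way, with a 3.1-fold lower number from compound 3 to compound 4 (0.49 log units; beyond the scatter) and, the largest of the new steps, a 12-fold lower number from compound 2 to compound 4 (1.07 log units; beyond the scatter), showing that methoxy and methyl, though both are attached through a small group, lie far apart here. Nothing measured for these compounds accounts for that difference.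

The compounds shown leave open whether a hydroxyl, an ethoxy group or a longer alkoxy chain at this carbon would lower the number further or return it towards that of compound 1. They also leave open whether methoxy would have the same effect on another carbon of this ring.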